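The source may report more compounds than this note shows. Statements on the series, on what has been measured and on what is new or still open speak of the compounds shown alone.

Measured compounds:
- compound 1 `C=CCc1cc(O)c(O)c(CN2CCC(CO)CC2)c1`: 21.9%
- compound 2 `C#CCOc1ccc(CC=C)cc1O`: 11.8%

In a functional assay on SK-N-SH cells (Homo sapiens) for inhibition, read by MTT assay, with a stated time of 72 h, tested at 30 uM (a lower number here means less inhibition of growth, a higher number more inhibition of growth at the concentration tested), compound 1 gives 21.9%, and compound 2 gives 11.8%. Compound 1 therefore holds the higher of the two numbers, and compound 2 sits below it by a margin beyond the usual scatter. The two share the allyl-bearing catechol core but differ in more than one place, so their gap cannot be assigned to any single change.

Compound 3 `C=CCc1cc(O)c(O)c(CN2CCC(Cc3ccccc3)CC2)c1` is the untested member. It differs from compound 1 in one place: phenyl in place of hydroxy on a saturated chain carbon bound to a saturated ring carbon. Among the compounds with values here, no measured pair in this assay isolates this kind of change, so its size in this assay is not anchored by data; the account can only note that the group entering is larger than the group leaving and carries no hydrogen-bond donor or acceptor.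

Within that uncertainty, compound 3 is expected to move upward from compound 1 by about a number 14.1 percentage points higher from compound 1 to compound 3 (beyond the scatter), a step of moderate size. The estimate for compound 3 in this assay is 36%, with a plausible range from 15% to 60%.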

Compound 3, percent growth inhibition at one concentration: 78.8%
Compound 3: middle estimate off by 42.8 percentage points, on the low side, and the stated range ends below it.
By their numbers in this assay, from the lowest: compound 2; then compound 1; then compound 3.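

The exchange of hydroxy for phenyl on a saturated chain carbon bound to a saturated ring carbon produces, in this assay, a number 56.9 percentage points higher from compound 1 to compound 3 (beyond the scatter), and this is the first step among these compounds that can be tied to one place. It shows that this place is far from indifferent to what it carries: with the hydroxymethyl of compound 1 read as a benzyl, compound 3 reaches 78.8%, so a change confined to the far end of the shared core moves the number by a large step. Nothing available here explains why the step is so large.

The compounds shown leave open whether the step belongs to the entering phenyl ring or simply to the loss of the hydroxy, and a plain methyl or ethyl at this place would be needed to separate the two. They also leave open how far the trend runs, for instance whether a longer chain carrying the phenyl, a fluorophenyl, or an amine in its place would hold, raise or lower the number in this assay.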